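Swapping the ketone-side trimethoxyphenyl for chlorophenyl

This account rests on a few compounds, and the source may have more. Where it says the series, first, only, none or still open, it means among the compounds named here.

Of the compounds shown here, three sharing one core have been tested in a functional assay on A549 cells (Homo sapiens) for antiproliferative activity, read by MTT assay, with a stated time of 24 h; on this read-out lower numbers stand for stronger inhibition and higher numbers for weaker inhibition. Compound 1 `COc1ccc(-c2cc(/C=C/C(=O)c3cc(OC)c(OC)c(OC)c3)nc3cc(-c4ccccc4)nn23)cc1OC` gives 7200 nM, the lowest of the three numbers. Compound 3 `COc1ccc(-c2cc(/C=C/C(=O)c3ccccc3)nc3cc(-c4ccccc4)nn23)cc1` gives 8600 nM, which sits within the scatter of compound 1, so no order between them can be claimed. Compound 2 `COc1cc(-c2cc(/C=C/C(=O)c3ccccc3)nc3cc(-c4ccccc4)nn23)cc(OC)c1OC` gives 18200 nM, beyond the scatter above compound 1.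

For the measured compounds named here, the only single-change step measured so far is a 2.1-fold lower number from compound 2 to compound 3 (0.33 log units; beyond the scatter). That step concerns the ring on an aromatic carbon, not the ring on the carbonyl carbon, so it bears only loosely on the present question. Compound 1 and compound 3 differ at both rings at once, and their two values lie within the scatter of each other; this hints that changing the ring on the carbonyl carbon may matter little here, but it is only a hint.

Compound 4 `COc1ccc(-c2cc(/C=C/C(=O)c3ccc(Cl)cc3)nc3cc(-c4ccccc4)nn23)cc1OC` is the unmeasured compound. Its change from compound 1 is 4-chlorophenyl in place of 3,4,5-trimethoxyphenyl on a carbonyl carbon. Going by the values given here, with no measured step at this position, the expected step is a 1.3-fold higher number from compound 1 to compound 4 (0.10 log units; within the scatter), that is none beyond the scatter. In this assay compound 4 is therefore estimated at 9000 nM, with a range from 4000 nM to 20000 nM.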

Compound 4, half-maximal inhibitory concentration: 15400 nM
The estimate for compound 4 lay 1.7-fold (0.23 log units) below the measured number, within the range that was stated.
By their numbers in this assay, from the lowest: compounds 1, 3, 4 and 2 (each within the scatter of the next, the first and the last beyond it).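

For the compounds shown here, this is the first measured step at the ring on the carbonyl carbon: in this assay, there is a 2.1-fold higher number from compound 1 to compound 4 (0.33 log units; beyond the scatter). It shows that, with everything else in the molecule held fixed, replacing 3,4,5-trimethoxyphenyl with 4-chlorophenyl gives weaker inhibition, so the earlier hint that this ring might matter little does not hold for this pair, although the step is modest. The swap changes several things at once, going from 12 heavy atoms and 3 hydrogen-bond acceptors to 7 heavy atoms and 0 acceptors, with chlorine entering and oxygen leaving, and no evidence is available to show which of these changes accounts for the step.

Going by these compounds, what remains open is whether the loss follows the departure of the methoxy groups, the arrival of the chlorine, or both, and whether the same swap would give a step of similar size with the other aromatic ring found in compound 2 or compound 3. It is also unknown how this position would respond to a ring carrying an amine or a carboxylic acid.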